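This account rests on a few compounds, and the source may have more. Where it says the series, first, only, none or still open, it means among the compounds named here.

Working notes on the series. Going by the values given here, in a functional assay on CNE-2 cells (Homo sapiens) for cytotoxicity, read by MTT assay, with a stated time of 72 h (a higher number here means a weaker inhibitor, a lower number a stronger inhibitor), compound 1 `O=C(NC(=S)NNc1ncnc2ccccc12)c1cccc(Cl)c1` gives 2920 nM, the lowest of the three numbers measured so far. Compound 3 `COc1cc2ncnc(NNC(=S)NC(=O)c3ccc(Cl)cc3)c2cc1OC` gives 7530 nM, and compound 2 `COc1cc2ncnc(NNC(=S)NC(=O)c3ccccc3Cl)c2cc1OC` gives 9670 nM; both of these sit beyond the scatter above compound 1, and both carry a core different from that of compound 1. Among the compounds with values here, the only measured step between compounds that differ in one place is a 1.3-fold lower number from compound 2 to compound 3 (0.11 log units; within the scatter), so on the core of compound 2 the exchange of one chlorophenyl for another on the carbonyl carbon did not move the number beyond the scatter.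

Compound 4 `O=C(NC(=S)NNc1ncnc2ccccc12)c1ccccc1Cl` is not yet measured; it differs from compound 1 as follows: 2-chlorophenyl in place of 3-chlorophenyl on a carbonyl carbon. Within the data shown here, no measured step on the core of compound 1 covers this exchange, and the step from compound 2 to compound 3 concerns a different pair of chlorophenyl groups on a different core. That step nevertheless bears on it, and since it stayed within the scatter, no step beyond the scatter is expected in this assay here either, with at most a slight lean toward a higher number because compound 2 gives 9670 nM. For compound 4 the estimate is 3600 nM, within 1500 nM to 8500 nM, which would mean an expected step of a 1.2-fold higher number from compound 1 to compound 4 (0.09 log units; within the scatter).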

Compound 4, half-maximal inhibitory concentration: 6090 nM
For compound 4 the middle estimate is 1.7-fold (0.23 log units) below the measured one; the range from low to high includes it.
By their numbers in this assay, from the lowest: compound 1; then compounds 4, 3 and 2 (each within the scatter of the next).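

In this assay, placing 2-chlorophenyl in place of 3-chlorophenyl on the carbonyl carbon gives a 2.1-fold higher number from compound 1 to compound 4 (0.32 log units; beyond the scatter) and shows that, on the core of compound 1, the number responds modestly to which chlorophenyl group is present. The earlier step of a 1.3-fold lower number from compound 2 to compound 3 (0.11 log units; within the scatter) showed no response beyond the scatter, but it involved a different pair of chlorophenyl groups on a different core, so the two steps do not establish a single pattern; the groups exchanged here also match in heavy atoms, hydrogen-bond donors, hydrogen-bond acceptors and charge, so these counts do not separate compound 1 from compound 4. The data at hand offer no evidence on what lies behind the step.

The compounds shown leave open how 4-chlorophenyl on the carbonyl carbon would read on the core of compound 1, which would connect this step with the one on the other core. They also leave open whether a phenyl group carrying an amine or a carboxylic acid instead of chlorine would stay near these numbers or move well away from them.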